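From a silicon-bearing side chain to a cyclobutyl one

A few compounds are considered here, and "the series" means these few. Any claim that something is new, unique, unknown or untested is made for them only; others in the source may bear on it.

Compound 1 `CN[C@H](CNc1cc(F)c(S(=O)(=O)Nc2ncc(F)s2)cc1Cl)C[Si](C)(C)C` stands alone among the measured compounds in giving a single number: in an ADME assay on HEK293 cells for inhibition of sodium channel protein type 8 subunit alpha (Homo sapiens), read by patch clamp, with a stated time of 5 min (on this read-out lower numbers stand for stronger inhibition and higher numbers for weaker inhibition), compound 1 gives 3130 nM. Compound 2 `O=S(=O)(Nc1nccs1)c1cc(Cl)c(NCC2CCCN2)cc1F`, a compound with a different side chain, reaches only a limit of this assay, > 34000 nM; > 34000 nM (2 entries), in both of its two entries, so no number is known for it. Going by the values given here, no step between two measured compounds is available here, and compound 2 differs from compound 1 in more than one place, so its limit says nothing about the change now considered.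

Compound 3 `CN[C@H](CNc1cc(F)c(S(=O)(=O)Nc2ncc(F)s2)cc1Cl)CC1CCC1` differs from compound 1 by a group of 4 heavy atoms (4 carbon; one four-membered non-aromatic ring of carbon only) in place of a group of 4 heavy atoms (3 carbon, 1 silicon; no ring), on a saturated chain carbon, two bonds along the chain from an amine nitrogen. Among the compounds with values here, with no measured step to guide it, the expected step of a 1.1-fold higher number from compound 1 to compound 3 (0.05 log units; within the scatter) is taken as none beyond the usual scatter, in either direction. Compound 3 is therefore estimated at 3500 nM, with a range from 1200 nM to 10000 nM.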

Compound 3, half-maximal inhibitory concentration: > 34000 nM
Compound 3: no number, only a limit (the forecaster's own chance of this, stated with the estimate: 10%); at least 9.7-fold (0.98 log units) between middle value and limit.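

In this assay, cyclobutyl in place of the silicon-bearing group on this saturated chain carbon gives an at least 10-fold higher number from compound 1 to compound 3 (1.03 log units; beyond the scatter), a first sign that the read-out at this position responds strongly to a change between two groups of 4 heavy atoms. Compound 3 gives > 34000 nM, which is a limit of the assay and not a number. The step is therefore only a lower bound on the true difference, and it rests on such a limit: the limit of > 34000 nM in this assay, at which 1 of the 3 values shown sits.

The compounds shown leave open whether the step follows from the ring or from the loss of silicon; a tert-butyl group, all carbon and without a ring, would separate the two. They also leave open how a cyclopropyl or a cyclopentyl group would read at this position.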